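Methylsulfanyl in Place of a Selenium Group: Growth Inhibition

This account rests on a few compounds, and the source may have more. Where it says the series, first, only, none or still open, it means among the compounds named here.

Compound 1 `CS/C(=N\C(=O)c1ccno1)NC(=O)c1ccno1` and compound 2 `O=C(/N=C(/NC(=O)c1ccno1)[Se]Cc1ccccc1)c1ccno1` share one core and differ only at a carbon with a double bond to nitrogen. In an ADME assay on MCF-10A cells (Homo sapiens) for cytotoxicity, read by MTT assay, with a stated time of 72 h (a higher number here means a weaker inhibitor of growth, a lower number a stronger inhibitor of growth), compound 1 gives a limit of the assay, > 100000 nM. In this assay compound 2 likewise gives only a limit, > 100000 nM. The change between them, (a group of 2 heavy atoms (1 carbon, 1 sulfur; no ring) in place of a group of 8 heavy atoms (7 carbon, 1 selenium; one six-membered aromatic ring of carbon only), on a carbon with a double bond to nitrogen), therefore made a step that the two limits leave unreadable from compound 2 to compound 1, and it cannot be read because of the limit of > 100000 nM in this assay, at which 2 of the 3 values shown sit.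

Compound 3 `O=C(/N=C(/NC(=O)c1cc(-c2ccccc2)nc2ccccc12)[Se]Cc1ccccc1)c1cc(-c2ccccc2)nc2ccccc12` carries the same selenium group on a different core; the difference between its core and that of compound 2 is not broken down here. In this assay, among the measured compounds shown here, compound 3 gives 45600 nM, the only number among the three measured compounds.

Compound 4 `CS/C(=N\C(=O)c1cc(-c2ccccc2)nc2ccccc12)NC(=O)c1cc(-c2ccccc2)nc2ccccc12` applies the same change to compound 3: a group of 2 heavy atoms (1 carbon, 1 sulfur; no ring) in place of a group of 8 heavy atoms (7 carbon, 1 selenium; one six-membered aromatic ring of carbon only), on a carbon with a double bond to nitrogen. The place is the same as in the earlier pair, so this is the same change.

For compound 4 the expectation rests on little: the earlier step sits at the limit and gives no size, so the step of a 1.1-fold higher number from compound 3 to compound 4 (0.04 log units; within the scatter) is estimated as small. Compound 4 is therefore expected to give about 50000 nM in this assay, with a range from 20000 nM to 120000 nM, and the chance that only a limit is reported is real given that compound 1 and compound 2 both sit at one.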

Compound 4, concentration for total growth inhibition: 540 nM
Beside the measured number, compound 4's estimate is 93-fold (1.97 log units) above it; the whole stated range lies above it.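

In this assay, putting methylsulfanyl in place of the selenium group on the carbon with a double bond to nitrogen gave an 84-fold lower number from compound 3 to compound 4 (1.93 log units; beyond the scatter), so on this core the change carries a large and clearly readable step. The same change on the core shared by compound 1 and compound 2 cannot be read, because neither compound gives a number, only a limit of the assay: the limit of > 100000 nM in this assay, at which 2 of the 4 values shown sit. The series therefore shows a sized effect of this change on one core only; it does not show that the step carries over from one core to another with the same size, or even in the same direction, and it offers no explanation for the step on the core of compound 3.

Going by these compounds, it remains open whether a longer chain on the sulfur, or an amine in the same place on the carbon with a double bond to nitrogen, would give a number close to that of compound 4 in this assay. It is also open how much of the step belongs to the selenium and how much to the six-membered aromatic ring, since the two leave together in both pairs and no compound shown separates them.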